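The source may report more compounds than this note shows. Statements on the series, on what has been measured and on what is new or still open speak of the compounds shown alone.

Growth inhibition measured in a functional assay on MCF7 cells (Homo sapiens) for inhibition, read by sulforhodamine B assay, with a stated time of 48 h, tested at 50 uM; a higher number here means more inhibition of growth at the concentration tested, a lower number less inhibition of growth

Compound 1 `COc1cc2c(cc1CCC(C)C)C(=O)C[C@@H](c1ccc(O)cc1)O2` gives 81%
Compound 2 `COc1ccc([C@@H]2CC(=O)c3cc(CC=C(C)C)c(OC)cc3O2)cc1` gives 65%
Compound 3 `COc1cc2c(cc1CC=C(C)C)/C(=N/NC(N)=O)C[C@@H](c1ccc(O)cc1)O2` gives 93%

Of these three, compound 3 (93%) stands highest. Compound 1 (81%) lies lower by more than the usual scatter, and compound 2 (65%) also lies beyond the scatter from compound 3.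

The unmeasured compound 4 (`COc1cc2c(cc1CC=C(C)C)/C(=N/O)C[C@@H](c1ccc(O)cc1)O2`) departs from compound 3 in one place, with hydroxy in place of ureido on a double-bonded nitrogen. Within the data shown here, neither compound 1 nor compound 2 carries a group on a double-bonded nitrogen, and both differ from compound 3 elsewhere, so no measured step isolates this change.

Compound 3 (93%) already lies near the top of the scale, so in this assay a moderate step downward is expected, with little room upward. Compound 1 (81%) reaches a high number without a ureido group, which argues against a collapse, although compound 2 (65%) also lacks one and sits lower, which keeps the range wide. The expected step is estimated as follows (a number 11 percentage points lower from compound 3 to compound 4 (beyond the scatter)). Compound 4 is therefore estimated at 82% (expected range 65% to 95%).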

Compound 4, percent growth inhibition at one concentration: 93%
Compound 4: the middle estimate sits 11 percentage points below what was measured; measured number inside the range.
By their numbers in this assay, from the lowest: compound 2; then compound 1; then compounds 3 and 4 (each within the scatter of the next).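

In this assay, among these compounds, the one step that isolates this position reads no change at the digits printed from compound 3 to compound 4 (within the scatter), so exchanging ureido for hydroxy on the double-bonded nitrogen produces no change that can be told from the scatter. The earlier compounds shown here could not show this, as neither compound 1 nor compound 2 carries a group on that nitrogen and both differ from compound 3 elsewhere; the new step shows that the ureido group is not needed at this place to keep growth inhibition at this level, and that the much smaller hydroxy serves as well in this read-out. No measurement shown here explains why the two groups give matching results.

The compounds shown leave open whether a methoxy or an amine on the double-bonded nitrogen would also match hydroxy and ureido. With compound 3 and compound 4 both close to the top of the scale at a single tested concentration, they also leave open whether the two would still match at lower concentrations, where any difference between them might appear.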